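This account rests on a few compounds, and the source may have more. Where it says the series, first, only, none or still open, it means among the compounds named here.

Compound 1 `COc1ccccc1/C=C(\C(=O)c1ccc(Cl)cc1)S(=O)(=O)Cc1ccc(Cl)c(Cl)c1` and compound 2 `COc1ccccc1/C=C(\C(=O)c1ccc(Cl)cc1)S(=O)(=O)c1ccc(C)cc1` share a core and differ only in the group on the sulfonyl sulfur. In a functional assay on DU-145 cells (Homo sapiens) for inhibition, read by trypan blue exclusion, with a stated time of 96 h (a higher number here means a weaker inhibitor of growth, a lower number a stronger inhibitor of growth), compound 1 gives 1000 nM and compound 2 gives 1000 nM. The change 3,4-dichlorobenzyl in place of 4-methylphenyl on a sulfonyl sulfur therefore produced no change at the digits printed from compound 2 to compound 1 (within the scatter).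

Compound 3 `COc1cc(OC)c(/C=C(/Sc2ccc(C)cc2)C(=O)c2ccc(Cl)cc2)c(OC)c1` carries a different core, and the difference between its core and that of compound 2 is not broken down here. In this assay compound 3 gives > 100000 nM, which is a limit of the assay and not a number; compound 3 is the one that sits at the limit of > 100000 nM in this assay, at which 1 of the 3 values shown sits.

Compound 4 `COc1cc(OC)c(/C=C(/SCc2ccc(Cl)c(Cl)c2)C(=O)c2ccc(Cl)cc2)c(OC)c1` is reached from compound 3 by 3,4-dichlorobenzyl in place of 4-methylphenyl on a sulfur. This is the same kind of change as that from compound 2 to compound 1, though not the same: there the group sat on a sulfonyl sulfur, here on a sulfur whose other neighbour is a double-bonded chain carbon. Because the measured step of no change at the digits printed from compound 2 to compound 1 (within the scatter) was flat, the expected step of a number no higher from compound 3 to compound 4 (the limit leaves the size open) is also taken to be flat. Compound 4 is thus expected to give 100000 nM, estimated to lie between 30000 nM and 300000 nM, most likely again reported only as a limit.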

Compound 4, concentration for 50% growth inhibition: 10000 nM
The estimate for compound 4 lay 10-fold (1.00 log units) above the measured number, and the stated range ends above it.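

In this assay, 3,4-dichlorobenzyl in place of 4-methylphenyl gave an at least 10-fold lower number from compound 3 to compound 4 (1.00 log units; beyond the scatter), so the change did not carry over with the same size from one core to the other: the same change on two cores in this assay, no change at the digits printed (within the scatter) from compound 2 to compound 1 and an at least 10-fold lower number (1.00 log units; beyond the scatter) from compound 3 to compound 4, at least 10-fold (1.00 log units) apart, beyond the scatter of two such steps

From the compounds shown here alone, compound 3 gives > 100000 nM, which is a limit of the assay and not a number, and the full size of the new step stays unknown. This one pair of steps does not show why the outcome differs, as the cores differ in more than the state of the sulfur, and it says nothing about any third core.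

The compounds shown leave open whether the step on the core of compound 3 comes from the two chlorines or from the added carbon of the benzyl group, which a plain benzyl or a 4-methylbenzyl on the sulfur would separate. Also open, going by these compounds, is how a group of another kind at that place, such as an amine or a carboxylic acid, would read in this assay.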